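A few compounds are considered here, and "the series" means these few. Any claim that something is new, unique, unknown or untested is made for them only; others in the source may bear on it.

Measured compounds and their numbers in a functional assay on MDA-MB-468 cells (Homo sapiens) for cytotoxicity, read by MTT assay, with a stated time of 48 h; a lower number here means a stronger inhibitor, a higher number a weaker inhibitor:

compound 1 `Cc1cc(OCC(=O)Nc2nc(-c3ccc(Br)cc3)cs2)ccc1Cl`: 52100 nM
compound 2 `O=C(COc1ccc(F)cc1)Nc1nc(-c2ccc(Br)cc2)cs1`: 52100 nM
compound 3 `Cc1ccccc1OCC(=O)Nc1nc(-c2ccc(Br)cc2)cs1`: 44900 nM

The three compounds share one core and differ only in the aromatic group hanging from the oxygen on the saturated carbon. Their numbers sit within the usual scatter of one another, so no one of them can be set apart: a 1.2-fold lower number from compound 1 to compound 3 (0.06 log units; within the scatter), and a 1.2-fold lower number from compound 2 to compound 3 (0.06 log units; within the scatter). The third change among them, no change at the digits printed from compound 1 to compound 2 (within the scatter), tells the same story.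

Compound 4 `Cc1ccc(OCC(=O)Nc2nc(-c3ccc(Br)cc3)cs2)cc1` is the next member of this set. Compared with compound 3 the change is 4-methylphenyl in place of 2-methylphenyl on an oxygen on a saturated carbon. Going by the values given here, every measured step so far has altered exactly this group, and none of them moved the number beyond the scatter, so the same is expected here: no change in this assay beyond the scatter. Compound 4 is therefore estimated at about 46000 nM, with a range from 20000 nM to 105000 nM. This estimate means an expected step of a 1.0-fold higher number from compound 3 to compound 4 (0.01 log units; within the scatter).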

Compound 4, half-maximal inhibitory concentration: 44900 nM
For compound 4 the middle estimate is 1.0-fold (0.01 log units) above the measured one; the measured number falls inside the stated range.
By their numbers in this assay, from the lowest: compounds 3, 4, 1 and 2 (each within the scatter of the next).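

Going by these compounds alone, compounds 3 and 4 carry the same atoms joined differently, so this is the first step here that changes only the arrangement of the group on the oxygen, and in this assay it gives no change at the digits printed from compound 3 to compound 4 (within the scatter). The other two new comparisons agree: methyl in place of fluoro on an aromatic carbon gives a 1.2-fold lower number from compound 2 to compound 4 (0.06 log units; within the scatter), and 4-methylphenyl in place of 4-chloro-3-methylphenyl gives a 1.2-fold lower number from compound 1 to compound 4 (0.06 log units; within the scatter), so swapping among these methyl, fluoro and chloro patterns shows no effect beyond the scatter. No supporting measurement bears on why these numbers stay together.

Going by these compounds, it remains open whether an amine or a carboxylic acid on this aromatic ring, or a longer chain in place of the saturated carbon, would shift the number beyond the scatter. On these data alone, the bromo group, shared by all four compounds, also stays untested against alternatives such as methoxy.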